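Working notes: methyl addition from compound 1 to compound 3

The compounds below may be only part of what the source reports. "The series", "measured", "known", "first", "only" and "open" are said of these compounds alone.

compound 1 `COc1cccc(C=Cc2ccc3ccccc3c2)c1C(=O)O`: > 100000 nM
compound 2 `O=C(O)c1c(O)cccc1C=Cc1ccc2ccccc2c1`: 71000 nM

In an ADME assay on HepG2 cells (Homo sapiens) for cytotoxicity, read by resazurin assay, with a stated time of 24 h (on this read-out lower numbers stand for higher toxicity in this test and higher numbers for lower toxicity in this test), compound 1 gives > 100000 nM, which is a limit of the assay and not a number (the limit of > 100000 nM in this assay, at which 1 of the 2 values shown sits). Compound 2 gives 71000 nM in this assay. Within the data shown here, the only measured step, an at least 1.4-fold lower number from compound 1 to compound 2 (0.14 log units; that floor lies within the scatter), concerns a hydrogen in place of methyl on an oxygen on an aromatic ring. Among the measured compounds shown here, compound 3 `COc1cc(C)cc(C=Cc2ccc3ccccc3c2)c1C(=O)O` differs from compound 1 by methyl in place of hydrogen on an aromatic carbon, a change that no measured step covers. No step beyond the scatter is therefore expected in this assay. Compound 3 is estimated at 120000 nM, range 50000 nM to 250000 nM, an expected step that the limit leaves unreadable from compound 1 to compound 3.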

Compound 3, half-maximal cytotoxic concentration: 117000 nM
For compound 3 the middle estimate is 1.0-fold (0.01 log units) above the measured one; the range from low to high includes it.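

No step from compound 1 to compound 3 can be read in this assay, because the value of compound 1 is a limit of the assay and not a number: the limit of > 100000 nM in this assay, at which 1 of the 3 values shown sits.

The compounds shown leave open how large a step methyl in place of hydrogen on an aromatic carbon gives in this assay.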